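The source may report more compounds than this note shows. Statements on the series, on what has been measured and on what is new or still open speak of the compounds shown alone.

Measured so far in a functional assay on KBVIN cells (Homo sapiens) for antiproliferative activity, read by sulforhodamine B assay, with a stated time of 3 days; on this read-out higher numbers stand for weaker inhibition of growth and lower numbers for stronger inhibition of growth:
- compound 1 `O=C(Nc1ccc(C(F)(F)F)cc1)c1cccc(Nc2ncc(F)c(Nc3ccc(F)cc3)n2)c1` gives > 10000 nM as a limit
- compound 2 `O=C(Nc1cccc(Nc2ncc(F)c(Nc3ccc(F)cc3)n2)c1)c1cnccn1` gives 20100 nM as a number
- compound 3 `O=C(Nc1cccc(Nc2ncc(F)c(Nc3ccc(F)cc3)n2)c1)c1cccc([N+](=O)[O-])c1` gives 11400 nM as a number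

Compound 1 sits at the limit of > 10000 nM in this assay, at which 1 of the 3 values shown sits, and gives no number.

Among the measured compounds shown here, compound 3 stands level with compound 2, the only other compound with a number, and neither can be ranked over the other. Next is compound 4 `CN(C)c1ccc(C(=O)Nc2cccc(Nc3ncc(F)c(Nc4ccc(F)cc4)n3)c2)cc1` with 4-(dimethylamino)phenyl in place of 3-nitrophenyl on a carbonyl carbon, and 4-(dimethylamino)phenyl in place of 3-nitrophenyl on a carbonyl carbon gives the counted difference.

For the measured compounds named here, one measured step bears on this place, 3-nitrophenyl in place of pyrazin-2-yl on a carbonyl carbon, and it reads a 1.8-fold lower number from compound 2 to compound 3 (0.25 log units; within the scatter) with nothing larger seen there. With that single step inside the scatter, no step beyond the scatter is expected in this assay and no direction is favoured. The estimate amounts to a 1.0-fold lower number from compound 3 to compound 4 (0.02 log units; within the scatter) as the expected step. For compound 4 the estimated value is 11000 nM with an expected range from 4500 nM to 27000 nM and some chance of a limit instead of a number.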

Compound 4, concentration for 50% growth inhibition: > 10000 nM
Compound 4: no number, only a limit (the forecaster's own chance of this, stated with the estimate: 30%); the middle value does not contradict the limit.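

In this assay, among the compounds shown here, compound 4 gives > 10000 nM, a limit and not a number, so no step from compound 2 or compound 3 to compound 4 can be read. The compounds shown leave open whether any group on this carbonyl carbon separates beyond the scatter, with the limit recurring: the limit of > 10000 nM in this assay, at which 2 of the 4 values shown sit.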